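The source may hold more compounds than are shown below. What is called first, only, known or untested is meant among the compounds shown, and "the series" means these compounds.

Compound 1 `CNc1nc(-c2cc(OC)c(OC)c(OC)c2)c(-c2ccc(C)cc2)s1`: 19 nM
Compound 2 `CNc1nc(-c2cc(OC)c(OC)c(OC)c2)c(-c2ccc(OC)cc2)s1`: 34.3 nM
Compound 3 `COc1cc(-c2nc(C)sc2-c2ccc(C)cc2)cc(OC)c1OC`: 517 nM

These three compounds were tested in a functional assay on Jurkat cells (Homo sapiens) for antiproliferative activity, read by MTT assay, with a stated time of 72 h; on this read-out higher numbers stand for weaker inhibition and lower numbers for stronger inhibition. Compound 3 gives the highest number of the three, 517 nM, so it is the least inhibitory member of the set. Compound 4 `COc1ccc(-c2sc(C)nc2-c2cc(OC)c(OC)c(OC)c2)cc1` has not yet been measured. It differs from compound 3 at a single place: methoxy in place of methyl on an aromatic carbon. This is methoxy in place of methyl on an aromatic carbon, para to a large group.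

One measured step shows the same change, a 1.8-fold higher number from compound 1 to compound 2 (0.26 log units; within the scatter). That step lies within the scatter, but it is a single example, and it was seen with methylamino on the shared core. The other measured step, a 27-fold higher number from compound 1 to compound 3 (1.43 log units; beyond the scatter), is large, but it concerns methyl in place of methylamino, a different change. It shows that compound 3 sits at a weaker level, and it does not show whether the methoxy swap behaves the same way there. No step beyond the scatter is therefore expected in this assay, with at most a slight lean towards a higher number. The expected step is a 1.5-fold higher number from compound 3 to compound 4 (0.19 log units; within the scatter). The estimated value for compound 4 is 800 nM, with an expected range from 300 nM to 2200 nM.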

Compound 4, half-maximal inhibitory concentration: 1760 nM
Compound 4: the middle estimate sits 2.2-fold (0.34 log units) below what was measured, and the stated range covers the measured number.
By their numbers in this assay, from the lowest: compounds 1 and 2 (each within the scatter of the next); then compound 3; then compound 4.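

In this assay, the change from 4-methylphenyl to 4-methoxyphenyl now gives a 3.4-fold higher number from compound 3 to compound 4 (0.53 log units; beyond the scatter), a modest step beyond the scatter, so this swap at this position is not neutral on every core, as the earlier step alone might have suggested. Both examples of the change point towards a higher number, and their sizes cannot be told apart: the same change on two cores in this assay, a 1.8-fold higher number (0.26 log units; within the scatter) from compound 1 to compound 2 and a 3.4-fold higher number (0.53 log units; beyond the scatter) from compound 3 to compound 4, 1.9-fold (0.28 log units) apart, within the scatter of two such steps Methyl in place of methylamino now also has a second example, a 51-fold higher number from compound 2 to compound 4 (1.71 log units; beyond the scatter), which is large like the first, so its loss of inhibition carries over from the 4-methylphenyl series to the 4-methoxyphenyl series: the same change on two cores in this assay, a 27-fold higher number (1.43 log units; beyond the scatter) from compound 1 to compound 3 and a 51-fold higher number (1.71 log units; beyond the scatter) from compound 2 to compound 4, 1.9-fold (0.28 log units) apart, within the scatter of two such steps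

With only methyl and methoxy compared at this aromatic carbon, the compounds shown leave open what a fluorine, a hydroxyl or an ethoxy group would do there. They also leave open whether an amine other than methylamino, such as a plain amino or a dimethylamino group, would hold the low numbers seen with methylamino on the shared core.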